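The source may report more compounds than this note shows. Statements on the series, on what has been measured and on what is new or still open speak of the compounds shown alone.

Measured compounds:
- compound 1 `COCC#Cc1cc(C(O)(C(F)(F)F)C(F)(F)F)cnc1N1CCN(S(=O)(=O)c2ccc(N)nc2)CC1`: 15 mL.min-1.g-1
- compound 2 `CC(C)n1cc(-c2cc(C(O)(C(F)(F)F)C(F)(F)F)cnc2N2CCN(S(=O)(=O)c3ccc(N)nc3)CC2)cn1`: 38 mL.min-1.g-1
- compound 3 `NC(=O)c1cccc(-c2cc(C(O)(C(F)(F)F)C(F)(F)F)cnc2N2CCN(S(=O)(=O)c3ccc(N)nc3)CC2)c1`: 17 mL.min-1.g-1

These values come from an ADME assay (liver) for metabolic stability, with Liver microsome (Homo sapiens) as the target, using microsomes and NADPH, with a stated time of 30 min, tested at 1 uM; a higher number here means faster removal of the compound, a lower number slower removal. Compound 3 stands second highest of the three: one of its steps lies within the scatter (a 1.1-fold higher number from compound 1 to compound 3 (0.05 log units; within the scatter)) and the other beyond it (a 2.2-fold lower number from compound 2 to compound 3 (0.35 log units; beyond the scatter)). Compound 4 `Nc1ccc(S(=O)(=O)N2CCN(c3ncc(C(O)(C(F)(F)F)C(F)(F)F)cc3-c3ccc4sccc4c3)CC2)cn1` is not yet measured; it differs from compound 3 in one place: 1-benzothiophen-5-yl in place of 3-carbamoylphenyl on an aromatic carbon. Among the compounds with values here, no measured step involves a 1-benzothiophen-5-yl group, so the expectation rests only on the spread seen when this group is exchanged, which reached at most the modest size of a 2.5-fold higher number from compound 1 to compound 2 (0.40 log units; beyond the scatter). A modest rise is therefore expected, a 2.2-fold higher number from compound 3 to compound 4 (0.35 log units; beyond the scatter), giving an estimate for compound 4 of 38 mL.min-1.g-1 in this assay, within a range of 14 mL.min-1.g-1 to 100 mL.min-1.g-1.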

Compound 4, intrinsic clearance in microsomes: 48 mL.min-1.g-1
Beside the measured number, compound 4's estimate is 1.3-fold (0.10 log units) below it; measured number inside the range.
By their numbers in this assay, from the lowest: compounds 1 and 3 (each within the scatter of the next); then compounds 2 and 4 (each within the scatter of the next).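

In this assay, 1-benzothiophen-5-yl at this aromatic carbon gives clearly faster removal than two of the earlier groups: 3-carbamoylphenyl, a 2.8-fold higher number from compound 3 to compound 4 (0.45 log units; beyond the scatter), and 3-methoxyprop-1-yn-1-yl, a 3.2-fold higher number from compound 1 to compound 4 (0.51 log units; beyond the scatter). Against 1-isopropyl-1H-pyrazol-4-yl, the step lies within the scatter, a 1.3-fold higher number from compound 2 to compound 4 (0.10 log units; within the scatter), so two quite different ring groups now share the high end, while 3-carbamoylphenyl, also a ring group, stays at the low end. No measurement shown here explains this split.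

Still open, on these data alone, is where a carboxylic acid in place of the carbamoyl group, or a simple amine at this carbon, would fall.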